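This account rests on a few compounds, and the source may have more. Where it says the series, first, only, none or still open, it means among the compounds named here.

Measured so far in a functional assay on the whole organism for inhibition, with Rattus norvegicus as the target, read by paw edema, with a stated time of 30 min, at a dose of 20 mg/kg by the oral route; on this read-out lower numbers stand for a weaker effect and higher numbers for a stronger effect at the one dose given:

compound 1, `COc1ccc(OCC2=NCCO2)cc1`, gives 16.6%
compound 2, `Clc1ccc(OCC2=NCCO2)cc1`, gives 30.3%
compound 3, `Brc1ccccc1OCC1=NCCO1`, gives 20.1%

Of the three numbers, compound 3 stands second highest. Its nearest neighbour is compound 1, whose value in this assay lies within the scatter of that of compound 3; the furthest is compound 2, whose value lies beyond the scatter above that of compound 3. Among the compounds with values here, the only step measured between two compounds differing in one place is a number 13.7 percentage points higher from compound 1 to compound 2 (beyond the scatter), which is modest.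

Compound 4, `Cc1ccccc1OCC1=NCCO1`, differs from compound 3 by methyl in place of bromo on an aromatic carbon, on an aromatic carbon of a six-membered aromatic ring of carbon only, ortho to a group of 7 heavy atoms. Within the data shown here, none of the measured steps exchanges a bromo for a methyl, and none concerns a group placed ortho to a group of 7 heavy atoms, so the one measured step gives no direct guide. On that basis the step is expected to be a number 0.1 percentage points lower from compound 3 to compound 4 (within the scatter), that is, no change beyond the scatter. For compound 4 in this assay a value of 20% is estimated, within a range from 8% to 32%.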

Compound 4, a percentage reported as inhibition, in the whole organism at one dose (the size of the read-out at that dose, not a potency): 3.1%
Beside the measured number, compound 4's estimate is 16.9 percentage points above it, outside the stated range (below it).
By their numbers in this assay, from the lowest: compound 4; then compounds 1 and 3 (each within the scatter of the next); then compound 2.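

In this assay, methyl in place of bromo on an aromatic carbon, ortho to a group of 7 heavy atoms, gives a number 17 percentage points lower from compound 3 to compound 4 (beyond the scatter). This shows that the read-out at this place depends on which of these two groups is present, even though each has 1 heavy atom, 0 hydrogen-bond donors, 0 hydrogen-bond acceptors and no net charge, so these counts do not tell the two groups apart. No measurement at hand accounts for the drop.

The compounds shown leave open whether bromo raises the read-out or methyl lowers it, relative to a plain hydrogen at this place. They also leave open how an amine or a carboxylic acid on the same aromatic carbon would compare with bromo and methyl.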